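This account rests on a few compounds, and the source may have more. Where it says the series, first, only, none or still open, it means among the compounds named here.

The measured compounds and their values:

Compound 1 `Nc1ncnn2c([C@@H]3O[C@H](CO)C[C@H]3O)cc(-c3ccc(Cl)cc3)c12` — 24000 nM
Compound 2 `Nc1ncnc2c([C@@H]3O[C@H](CO)[C@@H](O)[C@H]3O)cn(-c3ccc(Br)cc3)c12` — > 64000 nM
Compound 3 `OC[C@H]1O[C@@H](c2cnn3c(O)ncnc23)[C@H](O)[C@@H]1O` — > 64000 nM

In an ADME assay on cells (Macrophage, Mus musculus) for cytotoxicity (on this read-out lower numbers stand for higher toxicity in this test and higher numbers for lower toxicity in this test), compound 1 gives 24000 nM. Among the compounds with values here, this is the only actual number in the set. Compound 2 reaches only a limit of this assay, > 64000 nM. Compound 3 likewise reaches only a limit of this assay, > 64000 nM. Within the data shown here, compound 1 therefore stands as the one compound whose toxicity is quantified, while the other two are described by the limit (the limit of > 64000 nM in this assay, at which 2 of the 3 values shown sit).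

Compound 4 `Nc1ncnn2c([C@@H]3O[C@H](CO)[C@@H](O)[C@H]3O)cc(-c3ccc(Cl)cc3)c12` has not yet been measured. It differs from compound 1 in one place: hydroxy in place of hydrogen on a saturated ring carbon. The hydroxy enters next to the ring atom that bears a hydroxy group and next to the ring atom that bears a hydroxymethyl group, two ring bonds from the ring oxygen.

Among the measured compounds shown here, no measured pair here shows this exact change, so the size of the step can only be guessed. Compound 2 and compound 3, which both carry a hydroxy at the corresponding place, sit at the limit, which leans toward lower toxicity in this assay. The step from compound 1 to compound 4 is thus expected to go toward lower toxicity, a 2.1-fold higher number from compound 1 to compound 4 (0.32 log units; beyond the scatter), though it might also stay within the scatter. Compound 4 is estimated at 50000 nM, with a range from 20000 nM to 130000 nM.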

Compound 4, half-maximal cytotoxic concentration: 5000 nM
Compound 4: middle estimate off by 10-fold (1.00 log units), on the high side; the measured number lies below the stated range.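

In this assay, putting hydroxy in place of hydrogen on this saturated ring carbon gives a 4.8-fold lower number from compound 1 to compound 4 (0.68 log units; beyond the scatter), and on this read-out that direction means higher toxicity in this test. Within the data shown here, this is the first direct reading of the change, and it shows that the position is not neutral: a single added hydroxy moves the value beyond the usual scatter. Compound 2 and compound 3 also carry a hydroxy at the corresponding place, but they differ from compound 4 in more than one place and so could not show this step, and their values are limits rather than numbers: the limit of > 64000 nM in this assay, at which 2 of the 4 values shown sit.

An amine or a methoxy group on this same ring carbon would show whether the step belongs to hydroxy in particular or to any group placed there. Also open, going by these compounds, is why the step goes in this direction, and whether the same change would have a similar effect on a core other than that of compound 1.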